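The source may hold more compounds than are shown below. What is called first, only, known or untested is meant among the compounds shown, and "the series" means these compounds.

Measured compounds:
Compound 1, `C[C@@H](C(=O)N[C@H](C#N)CC(N)=O)N(Cc1ccc(-c2cccc(F)c2F)cc1)S(=O)(=O)c1ccccc1`: in an assay on isolated protein for inhibition of legumain (Homo sapiens), with stated times of 2 min and 60 min (on this read-out lower numbers stand for stronger inhibition and higher numbers for weaker inhibition), compound 1 gives > 10000 nM, which is a limit of the assay and not a number.
Compound 2, `CCCS(=O)(=O)N(Cc1ccc(-c2cccc(F)c2)cc1)[C@@H](C)C(=O)N[C@H](C#N)CC(N)=O`: in this assay compound 2 gives > 10000 nM, again a limit rather than a measured number.

Compound 2 therefore stands at the limit on the numbers shown, and it is not alone there: the limit of > 10000 nM in this assay, at which 2 of the 2 values shown sit. Nothing in the two values shown places either compound at a measurable potency in this assay.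

Compound 3, `C[C@@H](C(=O)N[C@H](C#N)CC(N)=O)N(Cc1ccc(-c2cccc(F)c2)cc1)S(=O)(=O)c1ccccc1`, differs from compound 2 in one place: phenyl in place of propyl on a sulfonyl sulfur. Among the measured compounds shown here, no step between measured compounds is available to size this change. With both values shown sitting at the limit, the expectation is for no step beyond the scatter in this assay, and the estimate for compound 3 is expected to lie at the limit as well. Compound 3 is expected at 15000 nM, in the range from 5000 nM to 50000 nM. The step this estimate means, a step that the limit leaves unreadable from compound 2 to compound 3, is expected to stay within the usual scatter.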

Compound 3, half-maximal inhibitory concentration: > 10000 nM
Compound 3: only a limit was reported; the forecaster's own chance of this, stated with the estimate: 85%; the middle value lies beyond the limit too.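

In this assay no step can be read from compound 2 to compound 3 or from compound 1 to compound 3, as all three compounds give a limit and not a number: the limit of > 10000 nM in this assay, at which 3 of the 3 values shown sit.

The compounds shown leave open whether phenyl in place of propyl on a sulfonyl sulfur, or hydrogen in place of fluoro on an aromatic carbon, changes inhibition at all.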